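This account rests on a few compounds, and the source may have more. Where it says the series, first, only, none or still open, it means among the compounds named here.

In an ADME assay on HCT-116 cells (Homo sapiens) for cytotoxicity, read by CellTiter-Glo, with a stated time of 72 h (on this read-out lower numbers stand for stronger inhibition and higher numbers for weaker inhibition), compound 1 `Cc1cc(C)c(S(=O)(=O)N2CCC(N3CCC(CCO)CC3)CC2)c(C)c1` gives > 5000 nM, a limit of the assay and not a number. Compound 2 `Cc1ccc(C2CCN(S(=O)(=O)c3c(C)cc(C)cc3C)CC2)cc1` gives > 5000 nM, again only a limit. Going by the values given here, the single measured change, a step that the two limits leave unreadable from compound 1 to compound 2, therefore offers no size to carry forward. Compound 3 `Cc1cc(C)c(S(=O)(=O)N2CCC(N3CCN(C)CC3)CC2)c(C)c1` has 4-methylpiperazin-1-yl in place of 4-methylphenyl on a saturated ring carbon. Compound 1 and compound 2 both stand at the limit of > 5000 nM in this assay, at which 2 of the 2 values shown sit, so compound 3 is expected to remain weak as well. The expected change, a step that the limit leaves unreadable from compound 2 to compound 3, is none beyond the scatter. For compound 3 the estimate is 7000 nM, with an expected range of 3000 nM to 15000 nM.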

Compound 3, half-maximal inhibitory concentration: > 5000 nM
Compound 3: only a limit was reported; the forecaster's own chance of this, stated with the estimate: 90%; the middle value is on the limit's open side.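

Going by these compounds alone, no step among compound 1, compound 2 and compound 3 can be read, since each gives only a limit: the limit of > 5000 nM in this assay, at which 3 of the 3 values shown sit. The compounds shown leave open whether any group on that saturated ring carbon gives a measurable value in this assay.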